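From 3-Hydroxyphenyl to 4-Nitrophenyl on an Amide-Type Nitrogen

A few compounds are considered here, and "the series" means these few. Any claim that something is new, unique, unknown or untested is made for them only; others in the source may bear on it.

In a functional assay on microsomes from liver (Rattus norvegicus, strain Wistar) for inhibition, with a stated time of 15 min (a higher number here means a weaker inhibitor, a lower number a stronger inhibitor), compound 1 `COc1cc(C2CC(c3cc4ccccc4o3)=NN2C(=O)Nc2cccc(O)c2)ccc1O` gives 24000000 nM as its half-maximal inhibitory concentration. Compound 2 `COc1cc(C2CC(c3cc4ccccc4o3)=NN2C(=O)Nc2ccccc2O)ccc1O` gives 22000000 nM in the same measurement, which places the two level with each other. Compound 1 therefore has no measured neighbour standing apart from it beyond the scatter.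

Compound 3 `COc1cc(C2CC(c3cc4ccccc4o3)=NN2C(=O)Nc2ccc([N+](=O)[O-])cc2)ccc1O` has yet to be measured. It differs from compound 1 at a single place (4-nitrophenyl in place of 3-hydroxyphenyl on an amide-type nitrogen) with 4-nitrophenyl in place of 3-hydroxyphenyl on an amide-type nitrogen. Going by the values given here, the one measured step at this place is a 1.1-fold lower number from compound 1 to compound 2 (0.04 log units; within the scatter) and it replaces 3-hydroxyphenyl with 2-hydroxyphenyl. Among the compounds with values here, that step retains a hydroxyphenyl group, and no measured compound carries 4-nitrophenyl, so it is only a weak guide to the new change. On this limited evidence, no step beyond the scatter is expected in this assay in either direction, although the range has to stay wide. The expected step is a 1.2-fold lower number from compound 1 to compound 3 (0.08 log units; within the scatter) on this estimate. For compound 3 the estimated value is 20000000 nM with an expected range from 7000000 nM to 50000000 nM in this measurement.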

Compound 3, half-maximal inhibitory concentration: 113000000 nM
Compound 3: middle estimate off by 5.7-fold (0.75 log units), on the low side, outside the stated range (above it).
By their numbers in this assay, from the lowest: compounds 2 and 1 (each within the scatter of the next); then compound 3.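

In this assay, going by these compounds alone, the change to 4-nitrophenyl is the first at this position to move the number beyond the scatter, and it does so against both hydroxyphenyl compounds (a 4.7-fold higher number from compound 1 to compound 3 (0.67 log units; beyond the scatter)) and (a 5.1-fold higher number from compound 2 to compound 3 (0.71 log units; beyond the scatter)), which makes compound 3 the weakest inhibitor of the three. The position on the amide-type nitrogen is therefore not indifferent to the aryl group it carries, even though 2-hydroxyphenyl and 3-hydroxyphenyl stand level there, and the one departure seen so far runs towards weaker inhibition. Nothing at hand accounts for this shift.

The change from compound 1 to compound 3 replaces the hydroxyl with a nitro group and also alters where the substituent sits on the phenyl ring, so the compounds shown cannot separate these two differences. They also leave open whether a plain phenyl, or a phenyl carrying an amine or a carboxylic acid, would stay level with the hydroxyphenyl compounds or fall towards compound 3.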